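The source may hold more compounds than are shown below. What is called first, only, known or untested is meant among the compounds shown, and "the series" means these compounds.

Working notes on the oxime and hydrazone series.

Compound 1 `COc1ccc(/C(=N\OC(C)=O)c2ccc3c(ccn3C)c2)c(OC)c1OC` carries an acetoxy group on the double-bonded nitrogen of the shared core. In a functional assay on A549 cells (Homo sapiens) for cytotoxicity, read by XTT assay, with a stated time of 72 h (on this read-out lower numbers stand for stronger inhibition and higher numbers for weaker inhibition), compound 1 gives > 10000 nM, which is a limit of the assay and not a number. For the measured compounds named here, compound 2 `CCn1ccc2cc(/C(=N/N)c3ccc(OC)c(OC)c3OC)ccc21`, the free hydrazone with an ethyl group on the core nitrogen, is the only other compound with a value here. In this assay compound 2 gives > 10000 nM, again a limit and not a number. Going by the values given here, both results therefore rest on (the limit of > 10000 nM in this assay, at which 2 of the 2 values shown sit), so nothing in the data places either compound at a measurable concentration, and no step between measured compounds can be sized.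

Compound 3 `COc1ccc(/C(=N\NC(C)=O)c2ccc3c(ccn3C)c2)c(OC)c1OC` differs from compound 1 by acetamido in place of acetoxy on a double-bonded nitrogen. Among the compounds with values here, with no measured step to lean on, the expectation for compound 3 is no change beyond the scatter, a step that the limit leaves unreadable from compound 1 to compound 3. In this assay compound 3 is estimated at 12000 nM, with a range from 4000 nM to 40000 nM, most probably reported as a limit once more.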

Compound 3, half-maximal inhibitory concentration: > 10000 nM
Compound 3: only a limit was reported; the forecaster's own chance of this, stated with the estimate: 75%; the middle value does not contradict the limit.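

No step from compound 1 to compound 3 can be read, since the results for both compounds are limits of the assay and not numbers: the limit of > 10000 nM in this assay, at which 3 of the 3 values shown sit.

The compounds shown leave open whether acetamido and acetoxy on a double-bonded nitrogen differ at all, and at what concentration, if any, a member of this series would give a readable value.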